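A few compounds are considered here, and "the series" means these few. Any claim that something is new, unique, unknown or untested is made for them only; others in the source may bear on it.

For the measured compounds named here, compound 2 `CN(C)CCNc1ccnc2cc(Cl)ccc12` stands at the highest of the two numbers measured so far: in a functional assay on MCF7 cells (Homo sapiens) for cytotoxicity, read by sulforhodamine B assay, with a stated time of 48 h, in the presence of a further agent that is not named here (a lower number here means a stronger inhibitor of growth, a higher number a weaker inhibitor of growth), compound 2 gives 7540 nM. Its nearest neighbour is compound 1 `CCCCNc1ccnc2cc(F)ccc12`, which in this assay gives 3170 nM, a gap beyond the usual scatter. Compound 3 `CN(C)CCNc1ccnc2cc(F)ccc12` differs from compound 2 by fluoro in place of chloro on an aromatic carbon. Going by the values given here, no measured pair isolates this change, so nothing fixes its size or direction. The estimated step of a 1.3-fold lower number from compound 2 to compound 3 (0.10 log units; within the scatter) is expected to be small, if anything toward a lower number. Compound 3 is expected to give 6000 nM in this assay, within a range of 2500 nM to 15000 nM.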

Compound 3, concentration for 50% growth inhibition: 2640 nM
Compound 3: middle estimate off by 2.3-fold (0.36 log units), on the high side; the measured number falls inside the stated range.
By their numbers in this assay, from the lowest: compounds 3 and 1 (each within the scatter of the next); then compound 2.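

In this assay, fluoro in place of chloro on this aromatic carbon gives a 2.9-fold lower number from compound 2 to compound 3 (0.46 log units; beyond the scatter) as the first measured size and direction for this change. Dimethylamino in place of ethyl on the saturated chain carbon gives a 1.2-fold lower number from compound 1 to compound 3 (0.08 log units; within the scatter) and so does not separate the two side chains when fluoro is on the core. No evidence here bears on the reason for either result.

Still open, from the compounds shown here alone, is how a bromo or methoxy group on this aromatic carbon would compare with fluoro and chloro. Also open, going by these compounds, is whether a longer chain ending in dimethylamino would keep the number of compound 3.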